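A few compounds are considered here, and "the series" means these few. Any claim that something is new, unique, unknown or untested is made for them only; others in the source may bear on it.

Going by the values given here, compound 1 `CCS(=O)(=O)N[C@H]1CCCN(C(C)=O)[C@H]1CO[C@H]1CC[C@@H](C(C)C)CC1` is the only compound here with a number in a functional assay on CHO-K1 cells for agonist activity at Orexin receptor type 2 (Homo sapiens), read by FLIPR and calcium flux (a lower number here means that less compound is needed, a higher number that more compound is needed for the effect), where compound 1 gives 270 nM. Compound 2 `CCS(=O)(=O)N[C@@H]1CCCN(C(C)=O)[C@H]1CO[C@H]1CC[C@H](C(C)C)CC1` gives in this assay only a limit, namely > 30000 nM. Among the compounds with values here, the single measured step, an at least 110-fold higher number from compound 1 to compound 2 (2.04 log units; beyond the scatter), turns on configuration alone, as the fact that compounds 1 and 2 differ only in the configuration as drawn shows, and leaves the sulfonyl chain untouched. Compound 3 `CCCS(=O)(=O)N[C@H]1CCCN(C(C)=O)[C@H]1CO[C@H]1CC[C@@H](C(C)C)CC1` differs from compound 1 by methyl in place of hydrogen on a saturated chain carbon, two bonds along the chain from a sulfonyl sulfur. Within the data shown here, no measured step bears on that change, so in this assay no step beyond the scatter is expected, neither up nor down, which is the expected no change at the digits printed from compound 1 to compound 3 (within the scatter). Compound 3 is therefore estimated at 270 nM, between 90 nM and 800 nM.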

Compound 3, half-maximal effective concentration: 2500 nM
Estimate against measurement, compound 3: 9.3-fold (0.97 log units) below; the measured number lies above the stated range.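

The sulfonyl chain is not a silent place in this assay: going from ethylsulfonyl to propylsulfonyl gives a 9.3-fold higher number from compound 1 to compound 3 (0.97 log units; beyond the scatter). So one added methyl at the chain end, with the configuration kept as in compound 1, moves the number beyond the scatter, in the direction of more compound being needed. Nothing shown here gives a cause for this step.

From the compounds shown here alone, what a shorter methylsulfonyl, a longer butylsulfonyl or a branched isopropylsulfonyl chain would do remains open. So does whether the trend seen across these two chains extends to any other sulfonyl group.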